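Trimming a Phenyl to a Methyl on the Tetrazole

A few compounds are considered here, and "the series" means these few. Any claim that something is new, unique, unknown or untested is made for them only; others in the source may bear on it.

Of the compounds shown here, three built on a shared core have been tested in a functional assay on C6 cells (Rattus norvegicus) for cytotoxicity, read by MTT assay, with a stated time of 24 h, tested at 12 ug/mL; on this read-out lower numbers stand for a stronger effect and higher numbers for a weaker effect at the one concentration tested. Compound 1 `Cn1nnnc1SCC(=O)N/N=c1/scc(-c2ccc(C#N)cc2)n1-c1ccccc1` gives 53.9% in this assay. Compound 2 `O=C(CSc1nnnn1-c1ccccc1)N/N=c1/scc(-c2ccccc2)n1-c1ccccc1` gives 47.1%, the lowest of the three numbers, while compound 3 `N#Cc1ccc(-c2cs/c(=N/NC(=O)CSc3nnnn3-c3ccccc3)n2-c2ccccc2)cc1` gives 74.1%. The two changes already measured are modest but beyond the scatter: methyl in place of phenyl on an aromatic nitrogen produces a number 20.2 percentage points lower from compound 3 to compound 1 (beyond the scatter), and hydrogen in place of cyano on an aromatic carbon read in the other direction, cyano in place of hydrogen on an aromatic carbon, produces a number 27 percentage points higher from compound 2 to compound 3 (beyond the scatter). Compound 1 and compound 2 lie within the scatter of each other, so no order between them can be claimed.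

Compound 4 `Cn1nnnc1SCC(=O)N/N=c1/scc(-c2ccccc2)n1-c1ccccc1` has not yet been measured. For the measured compounds named here, it differs from compound 2 by methyl in place of phenyl on an aromatic nitrogen, which is the same change as the one from compound 3 to compound 1, made at the same place on the same five-membered aromatic ring with 4 nitrogen; the two cores differ only by hydrogen in place of cyano on an aromatic carbon. Because a number 20.2 percentage points lower from compound 3 to compound 1 (beyond the scatter) was the result of this change once, a step of similar direction and size is expected here, with some allowance for the different core and the scatter, so the estimated step is a number 14.1 percentage points lower from compound 2 to compound 4 (beyond the scatter). On that basis compound 4 is expected to give about 33% in this assay, most likely between 18% and 52%.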

Compound 4, a percentage reported as activity, at one concentration (the size of the read-out at that concentration, not a potency): 80.7%
Estimate against measurement, compound 4: 47.7 percentage points below; the whole stated range lies below it.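

In this assay, where a higher number means a weaker effect, methyl in place of phenyl on an aromatic nitrogen gives a number 33.6 percentage points higher from compound 2 to compound 4 (beyond the scatter), which runs opposite to the same change made on the core that carries the cyano group: the same change on two cores in this assay, a number 20.2 percentage points lower (beyond the scatter) from compound 3 to compound 1 and a number 33.6 percentage points higher (beyond the scatter) from compound 2 to compound 4, 53.8 percentage points apart, beyond the scatter of two such steps The cyano group tells the same story from its side, since hydrogen in place of cyano on an aromatic carbon gives a number 26.8 percentage points higher from compound 1 to compound 4 (beyond the scatter), while the same swap between the two compounds with phenyl on the tetrazole runs the other way: the same change on two cores in this assay, a number 27 percentage points higher (beyond the scatter) from compound 2 to compound 3 and a number 26.8 percentage points lower (beyond the scatter) from compound 4 to compound 1, 53.8 percentage points apart, beyond the scatter of two such steps This shows that, among these four compounds, the result of going from 1-phenyl-1H-tetrazol-5-yl to 1-methyl-1H-tetrazol-5-yl depends on whether the cyano group is present, so a step seen on one core cannot simply be carried to the other; it does not show why the two groups are linked this way, or how the change would behave on any further core.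

The compounds shown leave open whether an ethyl or a cyclopropyl group in place of the methyl would follow the core with cyano or the core with hydrogen. On these data alone, it is equally open what an amine or a carboxylic acid in place of the cyano group would do to the step from phenyl to methyl.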